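Replacing 2-carboxypiperidin-1-yl with (2-hydroxyethyl)amino on a shared core

The compounds below may be only part of what the source reports. "The series", "measured", "known", "first", "only" and "open" are said of these compounds alone.

In a functional assay on HeLa cells (Homo sapiens) for antiproliferative activity, read by CCK-8 assay, with a stated time of 48 h (a higher number here means a weaker inhibitor, a lower number a stronger inhibitor), three compounds share one core and differ in the group on a saturated chain carbon bound to an aromatic carbon. Compound 1 (`COc1ccc(/C=C\c2cc(OC)c(OC)c(OC)c2)cc1OCc1ccc(CNC(C)(C)C(=O)O)cc1`), with (1-carboxy-1-methylethyl)amino, gives > 10000 nM as a limit. Compound 2 (`COc1ccc(/C=C\c2cc(OC)c(OC)c(OC)c2)cc1OCc1ccc(CN2C[C@H](O)C[C@@H]2C(=O)O)cc1`), with 2-carboxy-4-hydroxypyrrolidin-1-yl, gives > 10000 nM as a limit. Compound 3 (`COc1ccc(/C=C\c2cc(OC)c(OC)c(OC)c2)cc1OCc1ccc(CN2CCCC[C@@H]2C(=O)O)cc1`), with 2-carboxypiperidin-1-yl, gives > 10000 nM as a limit. Compound 3 therefore has no number, only the limit of > 10000 nM in this assay, at which 3 of the 3 values shown sit, to mark its place.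

In compound 4 (`COc1ccc(/C=C\c2cc(OC)c(OC)c(OC)c2)cc1OCc1ccc(CNCCO)cc1`), (2-hydroxyethyl)amino stands in place of 2-carboxypiperidin-1-yl ((2-hydroxyethyl)amino in place of 2-carboxypiperidin-1-yl on a saturated chain carbon bound to an aromatic carbon). The measured steps offer no size to carry over: a step that the two limits leave unreadable from compound 1 to compound 2 and a step that the two limits leave unreadable from compound 1 to compound 3 and a step that the two limits leave unreadable from compound 2 to compound 3 are all there is. For the measured compounds named here, the only guide is that all three groups tested so far carry a carboxy unit, and compound 3 keeps it through a step that the two limits leave unreadable from compound 2 to compound 3 and remains at the limit, whereas the entering group has none. A move toward stronger inhibition in this assay is thus expected, with wide uncertainty. The expected change is an at least 6.6-fold lower number from compound 3 to compound 4 (0.82 log units; beyond the scatter) in that direction. For compound 4 the estimate is 1500 nM with an expected range from 100 nM to 15000 nM and a result at the limit remains possible.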

Compound 4, half-maximal inhibitory concentration: 4400 nM
Compound 4: the middle estimate sits 2.9-fold (0.47 log units) below what was measured, and the stated range covers the measured number.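

In this assay, compound 4 is the only one of the four shown with a number at this place on a saturated chain carbon bound to an aromatic carbon, and it gives 4400 nM, so this position can register a change in the group it carries. The change reads as an at least 2.2-fold lower number from compound 3 to compound 4 (0.35 log units; beyond the scatter), and likewise as an at least 2.2-fold lower number from compound 2 to compound 4 (0.35 log units; beyond the scatter) and as an at least 2.2-fold lower number from compound 1 to compound 4 (0.35 log units; beyond the scatter); the last of these involves no ring, since (1-carboxy-1-methylethyl)amino has none, so losing the ring of compound 3 is not needed to account for the step. Compound 1, compound 2 and compound 3, all bearing a carboxy unit, stop at a limit and not a number, so the steps among them cannot be read: the limit of > 10000 nM in this assay, at which 3 of the 4 values shown sit.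

The compounds shown do not separate the loss of the carboxylic acid from the arrival of the hydroxyl on a chain, since compound 2 carries both a hydroxyl and a carboxy unit and stays at its limit. On these data alone, a plain ethylamino group, a methyl ester of the acid, or a longer chain such as 3-hydroxypropylamino would bear on that question, and how far the number can fall at this place remains open.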